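Loss of chloro on the urea aryl ring in a cytotoxicity series

This account rests on a few compounds, and the source may have more. Where it says the series, first, only, none or still open, it means among the compounds named here.

The measured compounds:
compound 1, `CN(C)CCn1cnnc1-c1cc(Oc2ccc(NC(=O)Nc3ccc(Cl)c(C(F)(F)F)c3)cc2F)ccn1`, 3760 nM
compound 2, `CN(C)CCn1cnnc1-c1cc(Oc2ccc(NC(=O)Nc3cccc(C(F)(F)F)c3)cc2F)ccn1`, 11200 nM
compound 3, `CCN(CC)CCn1cnnc1-c1cc(Oc2ccc(NC(=O)Nc3ccc(Cl)c(C(F)(F)F)c3)cc2F)ccn1`, 6730 nM

Of the compounds shown here, three of one series have been measured in an ADME assay on WI-38 cells (Homo sapiens) for cytotoxicity, read by MTT assay, with a stated time of 72 h; on this read-out higher numbers stand for weaker inhibition and lower numbers for stronger inhibition. Compound 1 gives 3760 nM in this assay, compound 2 gives 11200 nM, and compound 3 gives 6730 nM. Compound 2 differs from compound 1 by hydrogen in place of chloro on an aromatic carbon; this change gave a 3.0-fold higher number from compound 1 to compound 2 (0.47 log units; beyond the scatter). Compound 3 differs from compound 1 in its core by diethylamino in place of dimethylamino on a saturated chain carbon, two bonds along the chain from an aromatic nitrogen; that change gave a 1.8-fold higher number from compound 1 to compound 3 (0.25 log units; within the scatter). Among the compounds with values here, compound 3 and compound 2 have no counted step between them; their two values lie within the scatter of each other.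

Compound 4, `CCN(CC)CCn1cnnc1-c1cc(Oc2ccc(NC(=O)Nc3cccc(C(F)(F)F)c3)cc2F)ccn1`, has not yet been measured. It differs from compound 3 by hydrogen in place of chloro on an aromatic carbon. The place of this change reads the same, word for word, as in the pair of compound 1 and compound 2, so the change is the same one, made on the core of compound 3 instead of the core of compound 1. The same change occurs twice among the four compounds, and only once with a measured step.

Within the data shown here, compound 4 is expected to show a 2.5-fold higher number from compound 3 to compound 4 (0.40 log units; beyond the scatter) in this assay, a step set beside the one already seen, because a 3.0-fold higher number from compound 1 to compound 2 (0.47 log units; beyond the scatter) is the only measured instance of the change. The expectation rests on a single pair, and on the modest size of a 1.8-fold higher number from compound 1 to compound 3 (0.25 log units; within the scatter), which suggests the core of compound 3 behaves much like the core of compound 1. Compound 4 is therefore estimated at 17000 nM, with a range from 8000 nM to 40000 nM.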

Compound 4, half-maximal inhibitory concentration: 6920 nM
Estimate against measurement, compound 4: 2.5-fold (0.39 log units) above; the measured number lies below the stated range.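

In this assay, hydrogen in place of chloro on the core of compound 3 gave a 1.0-fold higher number from compound 3 to compound 4 (0.01 log units; within the scatter), so the clear step seen on the core of compound 1 did not carry over to this core: the same change on two cores in this assay, a 3.0-fold higher number (0.47 log units; beyond the scatter) from compound 1 to compound 2 and a 1.0-fold higher number (0.01 log units; within the scatter) from compound 3 to compound 4, 2.9-fold (0.46 log units) apart, beyond the scatter of two such steps

Read the other way, diethylamino in place of dimethylamino gave a 1.6-fold lower number from compound 2 to compound 4 (0.21 log units; within the scatter), and this change too gave a different result depending on whether chloro was present: the same change on two cores in this assay, a 1.8-fold higher number (0.25 log units; within the scatter) from compound 1 to compound 3 and a 1.6-fold lower number (0.21 log units; within the scatter) from compound 2 to compound 4, 2.9-fold (0.46 log units) apart, beyond the scatter of two such steps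

Across these four compounds, then, the effect of losing chloro depends on the amine it is paired with, so a step measured on one core could not be transferred to the other; but this rests on a single square of compounds in one assay, and it shows neither why the two changes interact nor how the loss of chloro would behave on any further core.

On these data alone, it remains open whether the loss of chloro would again leave the number unchanged with dipropylamino or a pyrrolidine as the amine, or with a longer chain leading to it. As far as these compounds go, it is equally open whether bromo or methyl in place of chloro would follow compound 1 and compound 2 or compound 3 and compound 4.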